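The source may hold more compounds than are shown below. What is called first, only, known or untested is meant among the compounds shown, and "the series" means these compounds.

Of the compounds shown here, two share a core and have been measured in a functional assay on A549 cells (Homo sapiens) for antiproliferative activity, read by MTT assay, with a stated time of 72 h; a higher number here means a weaker inhibitor, a lower number a stronger inhibitor. Compound 1 `CNC(=O)c1cc(Oc2ccc(NC(=O)c3cc4cccnc4n(-c4ccc(F)c(Cl)c4)c3=O)cc2)ccn1` gives 1560 nM in this assay. Compound 2 `CCNC(=O)c1cc(Oc2ccc(NC(=O)c3cc4cccnc4n(-c4ccc(C(F)(F)F)cc4Cl)c3=O)cc2)ccn1` gives 3290 nM in this assay, which is the higher of the two numbers, meaning the weaker inhibitor of the pair; the gap to compound 1 lies beyond the usual scatter of such measurements.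

The next compound, compound 3 `CCNC(=O)c1cc(Oc2ccc(NC(=O)c3cc4cccnc4n(-c4ccc(F)c(Cl)c4)c3=O)cc2)ccn1`, has not yet been measured. It differs from compound 2 in one place: 3-chloro-4-fluorophenyl in place of 2-chloro-4-(trifluoromethyl)phenyl on an aromatic nitrogen. The group that leaves carries a trifluoromethyl and a chlorine; the group that enters carries a fluorine and a chlorine, and is smaller by three heavy atoms. Both groups have no hydrogen-bond donors or acceptors and no charge.

Within the data shown here, no pair of measured compounds differs only in this way, so there is no direct guide for the size of the step. The expectation is that the step from compound 2 to compound 3 in this assay is a 1.8-fold lower number from compound 2 to compound 3 (0.26 log units; within the scatter), a modest move toward a lower number. Compound 3 is therefore expected to give about 1800 nM in this assay, within a range from 700 nM to 4500 nM.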

Compound 3, half-maximal inhibitory concentration: 1920 nM
Beside the measured number, compound 3's estimate is 1.1-fold (0.03 log units) below it; the range from low to high includes it.
By their numbers in this assay, from the lowest: compounds 1, 3 and 2 (each within the scatter of the next, the first and the last beyond it).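

In this assay, among these compounds, compound 3 gives the first direct reading of a change at the aromatic nitrogen: 3-chloro-4-fluorophenyl in place of 2-chloro-4-(trifluoromethyl)phenyl is a 1.7-fold lower number from compound 2 to compound 3 (0.23 log units; within the scatter), so this exchange of one halogen-bearing phenyl for another cannot be told apart from repeat-measurement noise. Among the compounds shown here, compound 3 also gives the first reading at the other end of the molecule, where methyl in place of hydrogen on a saturated chain carbon bound to an amide-type nitrogen is a 1.2-fold higher number from compound 1 to compound 3 (0.09 log units; within the scatter), so neither single change has a size that can be read with confidence here. Nothing available explains these numbers or links them to a property of either group.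

All of the aryl groups on the aromatic nitrogen shown carry halogens, which leaves open what an unsubstituted phenyl, a methoxyphenyl or a saturated cyclohexyl group would do there. Going by these compounds, at the amide end, the effect of a longer chain such as propyl, or of a chain ending in an amine, also remains open.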